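The source may hold more compounds than are shown below. What is called first, only, known or untested is meant among the compounds shown, and "the series" means these compounds.

Measured so far:
compound 1 `Cc1nc(Nc2cccc(Cl)c2)sc1C(=O)/C=C/c1ccc(Cl)cc1`: > 25000 nM
compound 2 `COc1cccc(/C=C/C(=O)c2sc(Nc3cccc(Cl)c3)nc2C)c1`: > 25000 nM
compound 3 `Cc1nc(Nc2cccc(Cl)c2)sc1C(=O)/C=C/c1ccccc1`: > 25000 nM

In a functional assay on Bel-7402 cells (Homo sapiens) for cytotoxicity, read by MTT assay (a lower number here means a stronger inhibitor, a higher number a weaker inhibitor), compound 1 gives > 25000 nM, which is a limit of the assay and not a number. Compound 2 gives > 25000 nM, also a limit. Compound 3 gives > 25000 nM, a limit as well. Compound 2 therefore stands at the limit of > 25000 nM in this assay, at which 3 of the 3 values shown sit. Compound 4 `COc1cccc(/C=C/C(=O)c2sc(Nc3ccc(C)cc3)nc2C)c1` differs from compound 2 by 4-methylphenyl in place of 3-chlorophenyl on a nitrogen on an aromatic ring. The measured steps a step that the two limits leave unreadable from compound 1 to compound 2, a step that the two limits leave unreadable from compound 1 to compound 3 and a step that the two limits leave unreadable from compound 2 to compound 3 are all unreadable, and none of them changes the group on the nitrogen on an aromatic ring, so no size can be drawn from them for the present change. With every value at the limit, compound 4 is expected to sit at the limit too, the step that the limit leaves unreadable from compound 2 to compound 4 being an estimate only. Compound 4 is estimated at 40000 nM, between 15000 nM and 100000 nM.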

Compound 4, half-maximal inhibitory concentration: > 25000 nM
Compound 4 gave a limit, no number (the forecaster's own chance of this, stated with the estimate: 80%); the middle value does not contradict the limit.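

Compound 2 and compound 4 both give only a limit of the assay and no number, so the step between them cannot be read: the limit of > 25000 nM in this assay, at which 4 of the 4 values shown sit.

As far as these compounds go, whether any change to the shared core gives a number in this assay instead of a limit stays open.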